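Chlorophenyl in place of methylphenyl on the triazole nitrogen

The compounds below may be only part of what the source reports. "The series", "measured", "known", "first", "only" and "open" are said of these compounds alone.

Compound 1 `Cc1ccc(-n2nc(-c3ccc(C(F)(F)F)cc3O)nc2-c2ccccc2O)cc1` gives 71.5% in a functional assay on PC-12 cells (Rattus norvegicus) for cytotoxicity, read by MTT assay, with stated times of 2 h and 24 h, tested at 1 uM (on this read-out lower numbers stand for a weaker effect and higher numbers for a stronger effect at the one concentration tested), and compound 2 `COc1ccc(-n2nc(-c3ccc(C(F)(F)F)cc3O)nc2-c2ccccc2O)cc1` gives 69%; the two lie within the scatter of each other, as the step of a number 2.5 percentage points lower from compound 1 to compound 2 (within the scatter) shows. Compound 3 `Oc1cc(C(F)(F)F)ccc1-c1nc(-c2ccccc2O)n(-c2ccccc2Cl)n1` is not yet measured. It differs from compound 1 by 2-chlorophenyl in place of 4-methylphenyl on an aromatic nitrogen. Among the compounds with values here, the only measured step, a number 2.5 percentage points lower from compound 1 to compound 2 (within the scatter), concerns a different group at the same nitrogen-borne phenyl and stayed within the scatter. For compound 3 the expected step is a number 3.5 percentage points lower from compound 1 to compound 3 (within the scatter), none beyond the scatter. Compound 3 is therefore estimated at 68%, between 50% and 82%.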

Compound 3, a percentage reported as activity, at one concentration (the size of the read-out at that concentration, not a potency): 70.1%
For compound 3 the middle estimate is 2.1 percentage points below the measured one; low and high end bracket the measured number.
By their numbers in this assay, from the lowest: compounds 2, 3 and 1 (each within the scatter of the next).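

In this assay, 2-chlorophenyl in place of 4-methylphenyl on the aromatic nitrogen gives a number 1.4 percentage points lower from compound 1 to compound 3 (within the scatter), and 2-chlorophenyl in place of 4-methoxyphenyl gives a number 1.1 percentage points higher from compound 2 to compound 3 (within the scatter). Across these three compounds, then, a chlorine-bearing phenyl with its substituent at the 2-position fits the same narrow band as the two 4-substituted phenyls, so this nitrogen has now taken a halogen and a different substitution pattern with no step beyond the scatter. Nothing available explains this result. From the compounds shown here alone, whether a phenyl carrying an amine or a carboxylic acid, or a longer alkyl chain in place of the phenyl, would stay in this band remains open.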